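Stepping from compound 3 to compound 4

A few compounds are considered here, and "the series" means these few. Any claim that something is new, unique, unknown or untested is made for them only; others in the source may bear on it.

In a physicochemical assay for lipophilicity, read by HPLC, at pH 7.5 (on this read-out higher numbers stand for higher lipophilicity and lower numbers for lower lipophilicity), compound 3 `CC[C@@H](Nc1c(C#N)c(-c2ccc(-c3cccc(Cl)c3F)cc2)nc2cnccc12)C(N)=O` gives 3.1, compound 2 `CC[C@@H](Nc1c(C#N)c(-c2ccc(-c3cccc(C)c3F)cc2)nc2cnccc12)C(N)=O` gives 3 and compound 1 `CC[C@@H](Nc1c(C#N)c(-c2ccc(-c3ccccc3F)cc2)nc2cnccc12)C(N)=O` gives 2.7. Compound 3 lies within the scatter of compound 2, with a number 0.10 log units higher from compound 2 to compound 3 (within the scatter), and clear of compound 1. Compound 4 `CC[C@@H](Nc1c(C#N)c(-c2ccc(-c3ccc(F)cc3)cc2)nc2cnccc12)C(N)=O` carries 4-fluorophenyl in place of 3-chloro-2-fluorophenyl on an aromatic carbon. The closest evidence is a number 0.40 log units higher from compound 1 to compound 3 (beyond the scatter), for chloro in place of hydrogen on an aromatic carbon. Compound 4, like compound 1, has no chloro, so a fall of similar size seems likely. Among the compounds with values here, no measured compound carries 4-fluorophenyl, so that part of the change is untested. The expected step is a number 0.40 log units lower from compound 3 to compound 4 (beyond the scatter). Compound 4 is estimated at 2.7, with an expected range of 2.4 to 3.1.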

Compound 4, distribution coefficient: 2.7
Compound 4: the middle estimate sits on the measured number at the digits printed; the range from low to high includes it.
By their numbers in this assay, from the lowest: compounds 1, 4, 2 and 3 (each within the scatter of the next, the first and the last beyond it).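

In this assay, 4-fluorophenyl in place of 2-fluorophenyl gives no change at the digits printed from compound 1 to compound 4 (within the scatter), so this read-out does not separate these two fluorophenyl groups. Against the larger groups the result splits: the replacement of 3-chloro-2-fluorophenyl gives a number 0.40 log units lower from compound 3 to compound 4 (beyond the scatter), whereas the replacement of 2-fluoro-3-methylphenyl gives only a number 0.30 log units lower from compound 2 to compound 4 (within the scatter). No supporting data are available to explain these steps.

Still open, as far as these compounds go, is whether chloro or methyl would give similar steps on the 4-fluorophenyl group. Also open, from the compounds shown here alone, is how an amine or a carboxylic acid on this ring would read.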